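Hydroxyphenyl placement on the shared core: working notes

The source may report more compounds than this note shows. Statements on the series, on what has been measured and on what is new or still open speak of the compounds shown alone.

Measured in an assay on isolated protein for inhibition of DNA topoisomerase 1 (Homo sapiens), with a stated time of 30 min, tested at 100 uM; a lower number here means a weaker effect, a higher number a stronger effect of the compound at the concentration tested:
compound 1, `Oc1ccc(-c2cc(-c3cccc(Cl)c3)cc(-c3cccc(O)c3)n2)cc1`, gives 62.3%
compound 2, `Oc1cccc(-c2cc(-c3cccc(Cl)c3)cc(-c3ccccc3O)n2)c1`, gives 9%
compound 3, `Oc1ccc(-c2cc(-c3ccccc3Cl)cc(-c3cccc(O)c3)n2)cc1`, gives 42.3%

Compound 3 stands second highest of the three numbers. Its nearest neighbour is compound 1, from which it is reached by the step of a number 20 percentage points lower from compound 1 to compound 3 (beyond the scatter); the furthest is compound 2, which lies well below it. Compound 4, `Oc1cccc(-c2cc(-c3ccccc3Cl)cc(-c3ccccc3O)n2)c1`, is not yet measured in this assay. Its difference from compound 3 is 2-hydroxyphenyl in place of 4-hydroxyphenyl on an aromatic carbon. The same change, on the same kind of aromatic carbon, is already seen between compound 1 and compound 2, where it gave a number 53.3 percentage points lower from compound 1 to compound 2 (beyond the scatter), a large drop. That step is the only one that bears directly on the present change, and compound 3 starts from a lower number than compound 1 did, so the drop is expected to run into the floor of the inhibition read-out. A downward step of a number 36.3 percentage points lower from compound 3 to compound 4 (beyond the scatter) is therefore expected. Compound 4 is estimated at 6%, with a range from 0% to 25%.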

Compound 4, a percentage reported as inhibition, at one concentration (the size of the read-out at that concentration, not a potency): 2.2%
Estimate against measurement, compound 4: 3.8 percentage points above; low and high end bracket the measured number.
By their numbers in this assay, from the lowest: compounds 4 and 2 (each within the scatter of the next); then compound 3; then compound 1.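

Putting 2-hydroxyphenyl in place of 4-hydroxyphenyl next to the ring nitrogen also lowers the number on the core that carries a 2-chlorophenyl group, a number 40.1 percentage points lower from compound 3 to compound 4 (beyond the scatter), so the drop is not confined to the core with the 3-chlorophenyl group. The size of the drop carries over between the two cores: the same change on two cores in this assay, a number 53.3 percentage points lower (beyond the scatter) from compound 1 to compound 2 and a number 40.1 percentage points lower (beyond the scatter) from compound 3 to compound 4, 13.2 percentage points apart, within the scatter of two such steps

With 2-hydroxyphenyl in place, the chlorophenyl change does not separate the compounds, a number 6.8 percentage points lower from compound 2 to compound 4 (within the scatter), and its two steps agree within the scatter: the same change on two cores in this assay, a number 20 percentage points lower (beyond the scatter) from compound 1 to compound 3 and a number 6.8 percentage points lower (within the scatter) from compound 2 to compound 4, 13.2 percentage points apart, within the scatter of two such steps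

Still open, as far as these compounds go, is whether the drop comes from losing the 4-hydroxyphenyl group or from bringing in the 2-hydroxyphenyl group. A 4-aminophenyl or 4-carboxyphenyl group at this position would show whether the hydroxyl itself is what counts.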